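This account rests on a few compounds, and the source may have more. Where it says the series, first, only, none or still open, it means among the compounds named here.

Measured compounds:
compound 1, `COc1ccc(OCC(=O)Nc2cccc(NC(=O)c3ccc(N(C)C)cc3)c2)cc1OC`, > 10000 nM
compound 2, `CC(C)(C)c1ccc(C(=O)Nc2cccc(NC(=O)COc3ccc4c(=O)ccoc4c3)c2)cc1`, 165 nM

The study concerns an assay on isolated protein for inhibition of Rho-associated protein kinase 1 (Homo sapiens), read by scintillation counting, radiometric assay and 33P incorporation, with a stated time of 40 min, in the presence of a further agent that is not named here; a higher number here means a weaker inhibitor, a lower number a stronger inhibitor. Compound 1 gives only a limit in this assay, > 10000 nM, and not a number. Compound 2, the carrier of the 4-(tert-butyl)phenyl group on the carbonyl carbon, gives 165 nM in this assay. This is the only number shown, since compound 1 contributes only a limit, as the limit of > 10000 nM in this assay, at which 1 of the 2 values shown sits, records. Compound 3, `CC(C)(C)c1cc(C(=O)Nc2cccc(NC(=O)COc3ccc4c(=O)ccoc4c3)c2)no1`, has not yet been measured. It differs from compound 2 in one place: 5-(tert-butyl)-1,2-oxazol-3-yl in place of 4-(tert-butyl)phenyl on a carbonyl carbon. Within the data shown here, no step between measured compounds is available to judge the effect of exchanging a six-membered carbon ring for a five-membered ring with two hetero atoms on that carbonyl carbon. He expects a modest loss, with the step of a 2.1-fold higher number from compound 2 to compound 3 (0.33 log units; beyond the scatter) estimated to lie close to the edge of the usual scatter. Compound 3 is therefore estimated at 350 nM in this assay, within a range from 90 nM to 1500 nM.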

Compound 3, half-maximal inhibitory concentration: 101 nM
Compound 3: the middle estimate sits 3.5-fold (0.54 log units) above what was measured; measured number inside the range.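

In this assay, 5-(tert-butyl)-1,2-oxazol-3-yl in place of 4-(tert-butyl)phenyl on a carbonyl carbon gives a 1.6-fold lower number from compound 2 to compound 3 (0.21 log units; within the scatter), so the two compounds cannot be told apart here. The earlier compounds shown here offered no step at this place; this first one shows that a five-membered aromatic ring with 2 hetero atoms can stand there in place of a six-membered aromatic ring of carbon only, with the tert-butyl group retained, and no clear difference in the read-out. Nothing given here bears on the reason for this outcome.

What the compounds shown leave open is whether the tert-butyl group itself matters, since both compounds carry it. On these data alone, how a methyl group, a cyclopropyl group or a dimethylamino group in its place would read also remains open.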